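The source may report more compounds than this note shows. Statements on the series, on what has been measured and on what is new or still open speak of the compounds shown alone.

Measured compounds in an ADME assay on microsomes from liver (Homo sapiens) for metabolic stability, tested at 2.5 uM; on this read-out higher numbers stand for fast clearance and lower numbers for slow clearance: compound 1 `COc1ccc(S(=O)(=O)c2cnc3c(F)cccc3c2-c2cccc(F)c2)cc1` gives 3.03 mL/min; compound 2 `O=S(=O)(c1ccc(F)cc1)c1cnc2c(F)cccc2c1-c1cccc(F)c1` gives 1.56 mL/min; compound 3 `O=S(=O)(c1cc(Cl)cc(Cl)c1)c1cnc2c(F)cccc2c1-c1cccc(F)c1` gives 1.08 mL/min.

Compound 3 has the lowest of the three numbers, though its gap to compound 2 lies within the scatter, and only its gap to compound 1 is beyond it. The step to compound 4 `N#Cc1cccc(S(=O)(=O)c2cnc3c(F)cccc3c2-c2cccc(F)c2)c1` changes the group on the sulfonyl sulfur: 3-cyanophenyl in place of 3,5-dichlorophenyl on a sulfonyl sulfur. The comparable exchanges on that sulfur were a 2.8-fold lower number from compound 1 to compound 3 (0.45 log units; beyond the scatter) and a 1.4-fold lower number from compound 2 to compound 3 (0.16 log units; within the scatter), so varying this group has moved this assay by modest amounts. A return toward the numbers of compounds 1 and 2 is therefore expected, that is a 1.7-fold higher number from compound 3 to compound 4 (0.22 log units; within the scatter). Compound 4 is estimated at 1.8 mL/min, with a range from 0.9 mL/min to 3.6 mL/min.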

Compound 4, intrinsic clearance in a liver preparation (reported as CLH), per the amount of preparation that the assay uses: 0.34 mL/min
Beside the measured number, compound 4's estimate is 5.3-fold (0.72 log units) above it; the whole stated range lies above it.
By their numbers in this assay, from the lowest: compound 4; then compounds 3, 2 and 1 (each within the scatter of the next, the first and the last beyond it).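

In this assay the 3-cyanophenyl group on the sulfonyl sulfur gives the lowest number of the four compounds, with a 3.2-fold lower number from compound 3 to compound 4 (0.50 log units; beyond the scatter) and a 4.6-fold lower number from compound 2 to compound 4 (0.66 log units; beyond the scatter) and an 8.9-fold lower number from compound 1 to compound 4 (0.95 log units; beyond the scatter). This position therefore spans a wider range than compounds 1 to 3 showed, and that range extends further toward slow clearance. Nothing measured here explains this drop.

As far as these compounds go, it remains open whether the nitrile or the loss of both chlorines matters more, and how a plain phenyl, an amide or an amine on that sulfur would read in this assay.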